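A few compounds are considered here, and "the series" means these few. Any claim that something is new, unique, unknown or untested is made for them only; others in the source may bear on it.

For the measured compounds named here, in an ADME assay on MT4 cells (Homo sapiens) for cytotoxicity, read by MTT assay (a higher number here means that more compound is tolerated, a lower number that less compound is tolerated), compound 1 (`O=C1c2ccccc2C(=O)N1CCOC(=S)N(C(=O)c1cc(F)ccc1F)c1ccc(Cl)cc1`) gives 54000 nM and compound 2 (`Cc1cc(C(=O)N(C(=S)OCCN2C(=O)c3ccccc3C2=O)c2ccc(Cl)cc2)ccc1Br`) gives 18000 nM, the lower of the two numbers so far. Compound 3 (`O=C1c2ccccc2C(=O)N1CCOC(=S)N(C(=O)c1cccc2ccccc12)c1ccc(Cl)cc1`) differs from compound 2 by naphthalen-1-yl in place of 4-bromo-3-methylphenyl on a carbonyl carbon. Going by the values given here, the only measured step, a 3.0-fold lower number from compound 1 to compound 2 (0.48 log units; beyond the scatter), also changes the group on a carbonyl carbon and is the sole guide. Among the compounds with values here, with no measurement yet for naphthalen-1-yl, no clear direction and no step beyond the scatter is expected in this assay. The expected step is a 1.1-fold higher number from compound 2 to compound 3 (0.05 log units; within the scatter). For compound 3 the estimate is 20000 nM, with an expected range of 8000 nM to 50000 nM.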

Compound 3, half-maximal cytotoxic concentration: 6000 nM
The estimate for compound 3 lay 3.3-fold (0.52 log units) above the measured number; the measured number lies below the stated range.
By their numbers in this assay, from the lowest: compound 3; then compound 2; then compound 1.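

In this assay, the group on a carbonyl carbon shifts the number again: naphthalen-1-yl gives a 3.0-fold lower number from compound 2 to compound 3 (0.48 log units; beyond the scatter) and a 9.0-fold lower number from compound 1 to compound 3 (0.95 log units; beyond the scatter). Across these three groups, compound 3, with two aromatic rings and no halogen, has the lowest number, and both of its steps lie beyond the scatter. Nothing at hand accounts for this order.

From the compounds shown here alone, whether the second ring or the absence of halogen goes with the lower number stays open. Also open, going by these compounds, is how a pyridine ring or a carboxylic acid at this place would read in this assay.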